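A few compounds are considered here, and "the series" means these few. Any claim that something is new, unique, unknown or untested is made for them only; others in the source may bear on it.

Compound 3, `CCCCNC(=O)CC1CCc2cc(OC)c(OC)cc21`, gives 24% in a functional assay on the whole organism (strain Wistar) for inhibition, with Rattus norvegicus as the target, read by paw edema, with stated times of 60 min and 2 h, at a dose of 100 mg/kg by the oral route (a higher number here means more inhibition at the dose given (going by the name of the read-out), a lower number less inhibition), the lowest of the three numbers in hand. Its nearest neighbour is compound 1, `COc1cc2c(cc1OC)C(CC(N)=O)CC2`, which gives 31%, and the step of a number 7 percentage points lower from compound 1 to compound 3 (within the scatter). Further off is compound 2, `COc1cc2c(cc1OC)C(CC(=O)NC(C)C)CC2`, which gives 37%; the step of a number 13 percentage points lower from compound 2 to compound 3 (beyond the scatter). Compound 4, `COc1cc2c(cc1OC)C(CC(=O)NC1CCCC1)CC2`, is not yet measured. It differs from compound 3 in one place: cyclopentyl in place of butyl on an amide-type nitrogen. Among the compounds with values here, the steps that bear on this are those that also change the group on the amide-type nitrogen: a number 6 percentage points higher from compound 1 to compound 2 (within the scatter), a number 7 percentage points lower from compound 1 to compound 3 (within the scatter) and a number 13 percentage points lower from compound 2 to compound 3 (beyond the scatter). Of these, only the exchange of isopropyl for butyl moved the number beyond the scatter, and modestly so. Within the data shown here, no measured step involves a ring on that nitrogen, so the expectation rests on the spread of these three numbers. Compound 4 is therefore expected to give a number in this assay near to or somewhat above that of compound 3, an estimated step of a number 6 percentage points higher from compound 3 to compound 4 (within the scatter), most likely within the scatter. The estimate for compound 4 is 30%, in a range from 18% to 42%.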

Compound 4, a percentage reported as inhibition, in the whole organism at one dose (the size of the read-out at that dose, not a potency): 52%
The estimate for compound 4 lay 22 percentage points below the measured number, and the stated range ends below it.
By their numbers in this assay, from the lowest: compounds 3, 1 and 2 (each within the scatter of the next, the first and the last beyond it); then compound 4.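

Within the data shown here, on the amide-type nitrogen, cyclopentyl is the first group to stand clear of all the others in this assay, with a number 28 percentage points higher from compound 3 to compound 4 (beyond the scatter), a number 15 percentage points higher from compound 2 to compound 4 (beyond the scatter) and a number 21 percentage points higher from compound 1 to compound 4 (beyond the scatter). Earlier, only the exchange of isopropyl for butyl had moved the number beyond the scatter, so this position proves able to carry a larger change than hydrogen and the two open-chain groups had shown, and the entering group differs from butyl by one five-membered ring and one carbon. Nothing measured here accounts for this gain.

The compounds shown leave open how a smaller ring such as cyclopropyl, a larger one such as cyclohexyl, or a ring carrying an amine would read on this nitrogen. They also leave open whether the gain would hold at other doses.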